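From 4-methylbenzyl to 3-fluoro-4-methylphenyl on the shared core

The source may hold more compounds than are shown below. What is called first, only, known or untested is meant among the compounds shown, and "the series" means these compounds.

Three compounds sharing one core have gone into an ADME assay on J774.A1 cells (Mus musculus) for cytotoxicity, read by MTT assay, with a stated time of 48 h (a lower number here means that less compound is tolerated, a higher number that more compound is tolerated), so far. Compound 1 `Cc1nc2ccccc2c(-c2ccccc2)c1C(=O)OCc1cn(-c2ccc(C(C)(C)C)cc2)nn1` is recorded as "not determined" (no result reported) in that test, and compound 2 `Cc1nc2ccccc2c(-c2ccccc2)c1C(=O)OCc1cn(Cc2ccccc2C#N)nn1` is recorded as "not determined" (no result reported) in that test. Only compound 3 `Cc1ccc(Cn2cc(COC(=O)c3c(C)nc4ccccc4c3-c3ccccc3)nn2)cc1` has a number, at 41000 nM with no other measured value to rank it against. Compound 4 `Cc1ccc(-n2cc(COC(=O)c3c(C)nc4ccccc4c3-c3ccccc3)nn2)cc1F` differs from compound 3 by a single exchange (3-fluoro-4-methylphenyl in place of 4-methylbenzyl on an aromatic nitrogen), with 3-fluoro-4-methylphenyl in place of 4-methylbenzyl on an aromatic nitrogen. Among the compounds with values here, with compound 3 at 41000 nM as the sole anchor and no measured pair showing this exchange, no step beyond the usual scatter is expected in this assay in either direction. The estimated move is small (a 1.0-fold lower number from compound 3 to compound 4 (0.01 log units; within the scatter)). For compound 4 the estimate is 40000 nM (expected range 15000 nM to 100000 nM).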

Compound 4, half-maximal cytotoxic concentration: 36000 nM
Compound 4: middle estimate off by 1.1-fold (0.05 log units), on the high side; measured number inside the range.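

In this assay, within the data shown here, the first measured pair at this position, 3-fluoro-4-methylphenyl in place of 4-methylbenzyl on an aromatic nitrogen gives a 1.1-fold lower number from compound 3 to compound 4 (0.06 log units; within the scatter), so the two compounds cannot be told apart in this test. At this one position, then, the tolerated concentration holds across this single exchange of an aryl group for a benzyl group. Nothing at hand bears on the reason for this result.

As far as these compounds go, whether an amine, a carboxylic acid or a longer chain on that nitrogen would also leave the number in place remains open.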